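A Sulfone Variant of Compound 2

The compounds below may be only part of what the source reports. "The series", "measured", "known", "first", "only" and "open" are said of these compounds alone.

Compound 1 `Cc1cc(Cl)c(NC(=O)N(Cc2ccc(Oc3ccc(F)cc3)cc2)C2CCCCCC2)c(Cl)n1` gives 14 nM in an assay for inhibition of acyl-CoA:cholesterol acyltransferase (Oryctolagus cuniculus), using microsomes; a higher number here means a weaker inhibitor, a lower number a stronger inhibitor. For the measured compounds named here, compound 2 `CSc1nc(C)cc(Cl)c1NC(=O)N(Cc1ccc(Oc2ccc(F)cc2)cc1)C1CCCCCC1` gives 12 nM in this assay; the only measured step, a 1.2-fold lower number from compound 1 to compound 2 (0.07 log units; within the scatter), lies within the scatter, so compound 2 stands on a par with compound 1 and nothing separates the two. Compound 3 `Cc1cc(S(C)(=O)=O)c(NC(=O)N(Cc2ccc(Oc3ccc(F)cc3)cc2)C2CCCCCC2)c(Cl)n1` differs from compound 2 by a group of 12 heavy atoms (7 carbon, 1 nitrogen, 2 oxygen, 1 sulfur, 1 chlorine; one six-membered aromatic ring with 1 hetero atom) in place of a group of 10 heavy atoms (7 carbon, 1 nitrogen, 1 sulfur, 1 chlorine; one six-membered aromatic ring with 1 hetero atom), on an amide-type nitrogen. Going by the values given here, no measured step bears on this change, and the one step known is flat, so the basis for an expectation is thin; a modest weakening is assumed, expected as a 2.5-fold higher number from compound 2 to compound 3 (0.40 log units; beyond the scatter). Compound 3 is therefore estimated at 30 nM, within 8 nM to 120 nM.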

Compound 3, half-maximal inhibitory concentration: 30 nM
The estimate for compound 3 equals the measured number at the digits printed; low and high end bracket the measured number.
By their numbers in this assay, from the lowest: compounds 2 and 1 (each within the scatter of the next); then compound 3.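

In this assay, putting methylsulfonyl where compound 1 carries chloro gives a 2.1-fold higher number from compound 1 to compound 3 (0.33 log units; beyond the scatter), so this position, flat for methylsulfanyl, does respond to a change of group, though only modestly. The wider comparison reads alike, with a 2.5-fold higher number from compound 2 to compound 3 (0.40 log units; beyond the scatter). No accompanying data bear on why the number rises.

From the compounds shown here alone, whether a smaller sulfur group such as methylsulfinyl would stay level with compound 1 remains open. So does how a nitrile or an amine on this aromatic carbon would fare.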